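The source may report more compounds than this note shows. Statements on the series, on what has been measured and on what is new or still open speak of the compounds shown alone.

Measured so far in a functional assay on the whole organism for inhibition, with Mythimna separata as the target, with a stated time of 5 days; on this read-out lower numbers stand for an effect already at smaller amounts and higher numbers for an effect only at larger amounts of compound:

Compound 1 `CC(C)(C)n1ncc(OCc2nnc(-c3ccc(Cl)cc3)s2)c(Cl)c1=O`: 106000 nM
Compound 2 `CC(C)(C)n1ncc(OCc2nnc(-c3cc(F)c(Cl)cc3Cl)s2)c(Cl)c1=O`: 67100 nM
Compound 3 `Cc1cc(C)cc(-c2nnc(COc3cnn(C(C)(C)C)c(=O)c3Cl)s2)c1`: > 299000 nM, a limit of the assay rather than a number

Going by these compounds, compound 3 stands at the weak end of what has been measured: in this assay compound 3 reached only the limit (the limit of > 299000 nM in this assay, at which 1 of the 3 values shown sits), so its true value is unknown and lies beyond that point. The step of an at least 2.8-fold higher number from compound 1 to compound 3 (0.45 log units; beyond the scatter) and the step of an at least 4.4-fold higher number from compound 2 to compound 3 (0.64 log units; beyond the scatter) both show that the 3,5-dimethylphenyl group on the shared core was at least modestly worse than the two chlorinated phenyl groups. Between compound 1 and compound 2 the difference a 1.6-fold lower number from compound 1 to compound 2 (0.20 log units; within the scatter) was small.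

Compound 4 `Cc1cccc(-c2nnc(COc3cnn(C(C)(C)C)c(=O)c3Cl)s2)c1` is compound 3 with one change: hydrogen in place of methyl on an aromatic carbon. Among the compounds with values here, no measured step removes a methyl from this ring, so the only guidance is that compound 3 sits at the limit and that both chlorinated analogues were better. A partial move away from the 3,5-dimethylphenyl pattern might recover some activity, but the evidence for that is thin. Compound 4 is therefore expected to remain weak, with a step of an at least 1.1-fold lower number from compound 3 to compound 4 (0.07 log units; that floor lies within the scatter) that is uncertain in size, and its estimated value is 250000 nM, ranging from 80000 nM to 800000 nM, with a real chance that only a limit is reported again.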

Compound 4, half-maximal effective concentration: > 299000 nM
Compound 4 was reported as a limit (the forecaster's own chance of this, stated with the estimate: 55%); middle value at least 1.1-fold (0.07 log units) from the limit.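

In this assay compound 4 gives > 299000 nM, which is a limit of the assay and not a number. Removing one methyl to leave a 3-methylphenyl group does not bring the compound level with the chlorinated analogues, with an at least 4.4-fold higher number from compound 2 to compound 4 (0.64 log units; beyond the scatter) and an at least 2.8-fold higher number from compound 1 to compound 4 (0.45 log units; beyond the scatter), so the shortfall seen with the 3,5-dimethylphenyl group does not depend on having both methyl groups. The step from compound 3 to compound 4 cannot be read, because neither compound gives a true number: the limit of > 299000 nM in this assay, at which 2 of the 4 values shown sit.

Going by these compounds, how far beyond the limit compound 3 and compound 4 really lie remains unknown, so it is still open whether one methyl differs at all from two on this ring. Also open, on these data alone, is whether methyl is the feature that matters, which could be tested by placing a chlorine, a methoxy group or an amine where the remaining methyl sits in compound 4, or by using a plain phenyl ring with no methyl at all.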